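Fluoro to methyl on the aryl ring of compound 1

This account rests on a few compounds, and the source may have more. Where it says the series, first, only, none or still open, it means among the compounds named here.

Working notes on a small set of triazolyl dithiocarbamates that share one core. Compound 1 `Fc1ccc(Cn2cc(CSC(=S)N3CCNCC3)nn2)cc1` is the parent with a free ring amine. In a functional assay on PC-3 cells (Homo sapiens) for inhibition, read by MTT assay, with a stated time of 72 h (on this read-out higher numbers stand for weaker inhibition and lower numbers for stronger inhibition), compound 1 gives only a limit, > 128000 nM, not a number. Compound 2 `O=C(OCc1ccccc1)N1CCN(C(=S)SCc2cn(Cc3ccc(F)cc3)nn2)CC1` carries a benzyloxycarbonyl on that amine nitrogen; in this assay compound 2 likewise gives a limit, > 128000 nM. Compound 3 `CC(C)(C)OC(=O)N1CCN(C(=S)SCc2cn(Cc3ccc(Cl)cc3)nn2)CC1` pairs a tert-butoxycarbonyl on the amine with a 4-chlorophenyl group; in this assay compound 3 again reaches only the limit, > 128000 nM. For the measured compounds named here, the single step between two measured neighbours, a step that the two limits leave unreadable from compound 1 to compound 2, cannot be read because the limit of > 128000 nM in this assay, at which 3 of the 3 values shown sit, holds both ends. So compound 1 stands at the limit, as does everything around it.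

Compound 4 `Cc1ccc(Cn2cc(CSC(=S)N3CCNCC3)nn2)cc1` differs from compound 1 by methyl in place of fluoro on an aromatic carbon, that is, 4-fluorophenyl to 4-methylphenyl. Going by the values given here, no measured step touches this aryl substituent; the only measured step concerns the amine and is itself unreadable. With every value in the set sitting at the limit of > 128000 nM in this assay, at which 3 of the 3 values shown sit, there is no basis for expecting compound 4 to move off it. Compound 4 is therefore estimated at 200000 nM, range 30000 nM to 1000000 nM, which is an expected step that the limit leaves unreadable from compound 1 to compound 4, and most likely another limit rather than a number.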

Compound 4, half-maximal inhibitory concentration: 19800 nM
Compound 4: the middle estimate sits 10-fold (1.00 log units) above what was measured; measured number below the stated range.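

In this assay, for the compounds shown here, the aryl substituent is the first place in this set where a change brings a compound off the limit: the swap of 4-fluorophenyl for 4-methylphenyl gives an at least 6.4-fold lower number from compound 1 to compound 4 (0.81 log units; beyond the scatter). The free ring amine is therefore compatible with a measurable number, so the limit seen for compound 1 does not hold for the whole free-amine subset, and the substituent on the aromatic carbon, para to a large group, matters to the read-out. The step remains a minimum and not a size, because its starting point is a limit and not a number: the limit of > 128000 nM in this assay, at which 3 of the 4 values shown sit.

Going by these compounds, whether methyl is special at this place remains open, as only fluoro and methyl can be compared here on the free-amine parent, and an ethyl, a methoxy or an amine at the same carbon would show whether the effect follows a wider trend. On these data alone, it is also open whether methyl in place of fluoro would lower the number for compound 2, where a benzyloxycarbonyl sits on the ring amine, since the step seen here applies only to the free amine.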